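Cyclohexyl for isobutyl on the acid-bearing carbon

The compounds below may be only part of what the source reports. "The series", "measured", "known", "first", "only" and "open" are said of these compounds alone.

Measured so far:
- compound 1, `COc1cccc(OC)c1-c1nc(C(=O)NC2(C(=O)O)CCCCC2)nc2ccc(Cl)cc12`: 959 nM
- compound 2, `COc1cccc(OC)c1-c1nc(C(=O)N[C@@H](CC(C)C)C(=O)O)nc2ccc(Cl)cc12`: 88 nM

Both compounds share the same core and differ only in the amino acid joined to the amide. In an assay on CHO-K1 cells for displacement of a labelled ligand from neurotensin receptor type 2 (Rattus norvegicus), read by radioligand binding (on this read-out lower numbers stand for stronger inhibition and higher numbers for weaker inhibition), compound 1 gives 959 nM, and compound 2 gives 88 nM. Going by the values given here, the single measured step, an 11-fold lower number from compound 1 to compound 2 (1.04 log units; beyond the scatter), is large, so compound 2 holds the lowest number of the two, with compound 1 as its only neighbour.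

Compound 3, `COc1cccc(OC)c1-c1nc(C(=O)N[C@H](C(=O)O)C2CCCCC2)nc2ccc(Cl)cc12`, is not yet measured. Relative to compound 2 the change is cyclohexyl in place of isobutyl on a saturated chain carbon bound to an amide-type nitrogen and a carbonyl carbon. This keeps the hydrogen on the acid-bearing carbon that compound 2 has and compound 1 lacks, and swaps one carbon-only group for another of similar kind. Among the compounds with values here, no measured step tests exactly this swap; the step from compound 1 to compound 2 changes both the substitution pattern and the group, so it bears on it only loosely. The expectation is therefore a step in this assay that stays within the usual scatter, a 1.3-fold lower number from compound 2 to compound 3 (0.10 log units; within the scatter). Compound 3 is estimated at 70 nM, with a range from 20 nM to 250 nM.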

Compound 3, inhibition constant: 474 nM
For compound 3 the middle estimate is 6.8-fold (0.83 log units) below the measured one; measured number above the stated range.
By their numbers in this assay, from the lowest: compound 2; then compound 3; then compound 1.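

In this assay, cyclohexyl and isobutyl turn out not to be interchangeable on a saturated chain carbon bound to an amide-type nitrogen and a carbonyl carbon, even though both are carbon-only groups with no hydrogen-bond donors or acceptors and no net charge (the swap gives a 5.4-fold higher number from compound 2 to compound 3 (0.73 log units; beyond the scatter)). Compound 3 also shows that the hydrogen kept on this carbon does not by itself bring back the low number of compound 2, although moving from the 1-carboxycyclohexyl of compound 1 to carboxy(cyclohexyl)methyl does lower the number somewhat (the change gives a 2.0-fold lower number from compound 1 to compound 3 (0.31 log units; beyond the scatter)), so the way the ring is attached matters as well as the ring's presence. Nothing available here accounts for either step.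

With only isobutyl and cyclohexyl to compare at this carbon, the compounds shown cannot tell whether the loss follows from the ring, from the number of carbons or from how close the branching lies to the chain carbon. Going by these compounds, how a methyl group, a longer n-butyl chain, a phenyl ring or an amine-bearing chain would read at this carbon remains open.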